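Swapping bromo for chloro on a tricyclic indole series

A few compounds are considered here, and "the series" means these few. Any claim that something is new, unique, unknown or untested is made for them only; others in the source may bear on it.

Of the compounds shown here, three have been measured in a functional assay on T47D cells (Homo sapiens) for inhibition, read by sulforhodamine B assay, with a stated time of 48 h; on this read-out higher numbers stand for weaker inhibition of growth and lower numbers for stronger inhibition of growth. Compound 1 `COC(=O)[C@@]1(C)CCC=C2[C@@H]1CC[C@@H](C)[C@]2(C)Cc1c(C)[nH]c2ccc(Br)cc12` gives 16000 nM, and compound 2 `COC(=O)[C@@]1(C)CCC=C2[C@@H]1CC[C@@H](C)[C@]2(C)Cc1c(C)[nH]c2ccc(Cl)cc12` gives 17000 nM. The step between them is chloro in place of bromo on an aromatic carbon, and it made a 1.1-fold higher number from compound 1 to compound 2 (0.03 log units; within the scatter). Compound 3 `COC(=O)[C@@]1(C)CCC=C2[C@@H]1CC[C@@H](C)[C@]2(C)Cc1c(C)[nH]c2c(Br)cccc12` gives 31000 nM; the difference between the cores of compound 1 and compound 3 is not broken down here. Compound 4 `COC(=O)[C@@]1(C)CCC=C2[C@@H]1CC[C@@H](C)[C@]2(C)Cc1c(C)[nH]c2c(Cl)cccc12` has not yet been measured. It differs from compound 3 by chloro in place of bromo on an aromatic carbon, the same kind of change as from compound 1 to compound 2, though the place differs: in the earlier pair it is meta to a fused ring and para to a fused ring, here ortho to a fused ring and meta to a fused ring. Because the earlier step gave a 1.1-fold higher number from compound 1 to compound 2 (0.03 log units; within the scatter), the step of a 1.1-fold higher number from compound 3 to compound 4 (0.03 log units; within the scatter) is expected to be small. Compound 4 is therefore estimated at 33000 nM in this assay, with a likely range from 15000 nM to 70000 nM.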

Compound 4, concentration for 50% growth inhibition: 27000 nM
Estimate against measurement, compound 4: 1.2-fold (0.09 log units) above, within the range that was stated.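

In this assay, chloro in place of bromo on the core of compound 3 gave a 1.1-fold lower number from compound 3 to compound 4 (0.06 log units; within the scatter) and so, as on the core of compound 1, made no change beyond the scatter. The swap therefore carries from one core to the other without a visible effect: the same change on two cores in this assay, a 1.1-fold higher number (0.03 log units; within the scatter) from compound 1 to compound 2 and a 1.1-fold lower number (0.06 log units; within the scatter) from compound 3 to compound 4, 1.2-fold (0.09 log units) apart, within the scatter of two such steps. This does not show that a change with a larger effect would carry over in the same way, and both steps are too small to reveal any shared direction.

Still open, from the compounds shown here alone, is whether an amine or a methoxy group on these aromatic carbons would shift growth inhibition beyond the scatter. Also open, going by these compounds, is what a carboxylic acid in place of the methyl ester would do.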